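This account rests on a few compounds, and the source may have more. Where it says the series, first, only, none or still open, it means among the compounds named here.

Measured compounds:
compound 1, `C=CCOc1cc(/C=C\c2cc(OC)c(OC)c(OC)c2)ccc1OC`, gives 29000 nM in a functional assay on HT-29 cells (Homo sapiens) for inhibition, read by MTT assay, with a stated time of 3 days; a lower number here means a stronger inhibitor, a higher number a weaker inhibitor;
compound 2, `COc1ccc(/C=C\c2cc(OC)c(OC)c(OC)c2)cc1OCc1ccc(Br)cc1`, gives 108000 nM in this assay.

Of these two numbers, compound 1 has the lower one, and the gap to compound 2 is beyond the scatter. For the measured compounds named here, the only step among the measured compounds, a 3.7-fold higher number from compound 1 to compound 2 (0.57 log units; beyond the scatter), replaced the vinyl on a saturated chain carbon bound to an oxygen on an aromatic ring with a larger aromatic group carrying a bromine, and the number rose.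

Compound 3, `COc1ccc(/C=C\c2cc(OC)c(OC)c(OC)c2)cc1OCCC/C=C/c1ccc(Br)cc1`, is not yet measured. It differs from compound 1 as follows: a group of 11 heavy atoms (10 carbon, 1 bromine; one six-membered aromatic ring of carbon only) in place of a group of 2 heavy atoms (2 carbon; no ring), on a saturated chain carbon bound to an oxygen on an aromatic ring. So the same position that was changed between compound 1 and compound 2 is changed again, and again a small two-carbon group gives way to a much larger group that holds a bromine-bearing aromatic ring, here joined through a longer chain with a double bond in it. Going by the values given here, the step from compound 1 to compound 2 is the only guide, and it points to a weaker inhibitor. The estimated step is a 3.4-fold higher number from compound 1 to compound 3 (0.54 log units; beyond the scatter), and compound 3 is expected to give about 100000 nM in this assay, with a likely range from 30000 nM to 300000 nM.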

Compound 3, half-maximal inhibitory concentration: 11000 nM
The estimate for compound 3 lay 9.1-fold (0.96 log units) above the measured number; measured number below the stated range.
By their numbers in this assay, from the lowest: compound 3; then compound 1; then compound 2.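

In this assay a bromine-bearing aromatic ring at this place does not by itself push the number up: there is a 2.6-fold lower number from compound 1 to compound 3 (0.42 log units; beyond the scatter) even though the incoming group is much larger than the vinyl it replaces. The direction of the change therefore does not follow from the size of the group alone, and the way the ring is attached counts too, since there is a 9.8-fold lower number from compound 2 to compound 3 (0.99 log units; beyond the scatter) when the ring sits at the end of a longer chain with a double bond in it instead of close to the oxygen. Nothing available explains why this longer attachment gives the lower number.

From the compounds shown here alone, compound 3 differs from compound 2 in chain length and in the double bond together, so what each contributes alone stays open, and a fully saturated chain of the same length would separate the two. Going by these compounds, it is also open whether the bromine matters at all, which a plain phenyl ring or an amine at the end of the same chain would help to test.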